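A few compounds are considered here, and "the series" means these few. Any claim that something is new, unique, unknown or untested is made for them only; others in the source may bear on it.

Among the measured compounds shown here, compound 1, with the structure `NCc1ccc(C(=O)Nc2ccncc2F)cc1-c1cccc(C(=O)Nc2ccc(CC(=O)O)cc2)c1`, is one of two compounds measured here in an assay on cells for inhibition of Rho-associated protein kinase 2 (Homo sapiens), read by radiometric assay and 33P incorporation, in the presence of a further agent that is not named here; a higher number here means a weaker inhibitor, a lower number a stronger inhibitor. In this assay compound 1 gives 1.8 nM. The second compound, compound 2, has the structure `COCCOC(=O)c1ccc(F)c(C(=O)Nc2cccc(-c3cc(C(=O)Nc4ccncc4F)ccc3CN)c2)c1`. For compound 2 the result in this assay is only a limit of the assay, < 1 nM, not a measured number. For the measured compounds named here, compound 1 therefore stands as the only compound with an actual number; the other value recorded is the limit of < 1 nM in this assay, at which 1 of the 2 values shown sits.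

The compound still to be measured is compound 3, with the structure `NCc1ccc(C(=O)Nc2ccncc2F)cc1-c1cccc(C(=O)Nc2ccccc2)c1`. It differs from compound 1 in one place: hydrogen in place of carboxymethyl on an aromatic carbon. Going by the values given here, no pair of measured compounds differing in only this one place is available, so the size of the step cannot be read from the data. Taking compound 1 at 1.8 nM as the starting point, the change is expected to give a step of a 2.2-fold higher number from compound 1 to compound 3 (0.35 log units; beyond the scatter), a small loss that may lie within the scatter. Compound 3 is therefore estimated at 4 nM in this assay, expected to fall between 1 nM and 15 nM.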

Compound 3, half-maximal inhibitory concentration: < 1 nM
Compound 3: no number, only a limit (the forecaster's own chance of this, stated with the estimate: 15%); middle value at least 4.0-fold (0.60 log units) from the limit.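

With hydrogen in place of carboxymethyl on an aromatic carbon, para to a large group, the data give an at least 1.8-fold lower number from compound 1 to compound 3 (0.25 log units; that floor lies within the scatter). Among the compounds shown here, the result for compound 3 in this assay is a limit of the assay and not a number, but it shows what the earlier compounds could not: on the core of compound 1, inhibition at this level does not depend on the carboxymethyl group, and the bare phenyl ring is enough. How large the step really is cannot be read, and no gain from the change can be claimed, because the assay stops giving numbers at this level: the limit of < 1 nM in this assay, at which 2 of the 3 values shown sit.

The compounds shown leave open how this position would respond to a carboxylic acid set directly on the ring, to an amine, or to a longer chain ending in a carboxylic acid. Also open, from the compounds shown here alone, is whether hydrogen in place of carboxymethyl would read the same way on a core other than that of compound 1.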